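The source may hold more compounds than are shown below. What is called first, only, known or untested is meant among the compounds shown, and "the series" means these compounds.

Measured so far in an ADME assay on HEK293 cells (Homo sapiens) for cytotoxicity, with a stated time of 72 h; on this read-out lower numbers stand for an effect already at smaller amounts and higher numbers for an effect only at larger amounts of compound:

Compound 1 `C=C[C@@](C)(/C=C/c1ccc(O)c(/C=C/C(=O)c2ccccc2)c1)CCC=C(C)C`: > 7410 nM, a limit
Compound 2 `C=C[C@@](C)(/C=C/c1ccc(O)c(/C=C/c2ccc(Cl)cc2)c1)CCC=C(C)C`: > 36600 nM, a limit

Compound 2 has no exact number on this read-out, since its > 36600 nM is a limit. Among the measured compounds shown here, the only other value shown, that of compound 1, is a limit as well, so neither compound can be placed precisely.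

Compound 3 `C=C[C@@](C)(/C=C/c1ccc(O)c(/C=C/C=C/c2ccccc2)c1)CCC=C(C)C` has not yet been measured. It differs from compound 2 in one place, on a double-bonded chain carbon bound to a double-bonded chain carbon: 2-phenylethenyl in place of 4-chlorophenyl on a double-bonded chain carbon bound to a double-bonded chain carbon. Neither the group that leaves nor the one that enters carries a net charge.

For the measured compounds named here, the one measured step at this place is a step that the two limits leave unreadable from compound 1 to compound 2. It offers no size to carry forward. The expectation therefore rests on compound 2 alone, with its limit of > 36600 nM. In this assay, no step beyond the usual scatter is expected, and no direction can be given. The estimated step is an at least 1.2-fold lower number from compound 2 to compound 3 (0.08 log units; that floor lies within the scatter). For compound 3 the expected value is 30000 nM, with an estimated range from 8000 nM to 100000 nM.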

Compound 3, half-maximal effective concentration: > 36600 nM
Compound 3: a limit, no number; the forecaster's own chance of this, stated with the estimate: 70%; middle value at least 1.2-fold (0.08 log units) away from the limit.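

The results for compound 1, compound 2 and compound 3 in this assay are all limits rather than numbers, so no step among them can be read: the limit of > 36600 nM in this assay, at which 2 of the 3 values shown sit.

The compounds shown leave open where each one's true value lies, and whether benzoyl, 4-chlorophenyl and 2-phenylethenyl differ at all in this cytotoxicity read-out.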